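The source may hold more compounds than are shown below. What is called first, only, known or untested is meant among the compounds shown, and "the series" means these compounds.

Measured so far in a toxicity assay on GES1 cells (Homo sapiens) for inhibition, read by CCK-8 assay, with a stated time of 72 h; on this read-out higher numbers stand for weaker inhibition and lower numbers for stronger inhibition:
compound 1 `CC(C)(C)OC(=O)N1CCN(C(=O)Cn2cc(CN3C(=O)C(=O)c4c(Cl)ccc(Cl)c43)nn2)CC1` gives 84200 nM
compound 2 `O=C1C(=O)N(Cc2cn(CC(=O)N3CCOCC3)nn2)c2c(Cl)ccc(Cl)c21` gives > 128000 nM
compound 3 `O=C(Cn1cc(CN2C(=O)C(=O)c3c(Cl)ccc(Cl)c32)nn1)NC1CCCCC1` gives 47400 nM

The value for compound 2 is a limit of the assay, not a number: the limit of > 128000 nM in this assay, at which 1 of the 3 values shown sits. Compound 3 has the lowest of the two numbers; its nearest neighbour is compound 1, whose number lies within the scatter of that of compound 3, so no order between these two is claimed.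

For the measured compounds named here, one measured step bears on the next compound: an at least 2.7-fold lower number from compound 2 to compound 3 (0.43 log units; beyond the scatter), a cyclic tertiary amide exchanged for a secondary amide with a carbocyclic ring. Compound 4 `O=C1C(=O)N(Cc2cn(CC(=O)N3CCCC3)nn2)c2c(Cl)ccc(Cl)c21` differs from compound 3 by pyrrolidin-1-yl in place of cyclohexylamino on a carbonyl carbon. This runs in the opposite sense to the step from compound 2 to compound 3, a cyclic tertiary amide again replacing the cyclohexylamino group. In this assay compound 4 is therefore expected to return toward the numbers of compound 1 and compound 2, the expected step being a 2.0-fold higher number from compound 3 to compound 4 (0.30 log units; within the scatter). The estimate for compound 4 is 95000 nM, in the range 45000 nM to 200000 nM, with a real chance that only a limit is reported.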

Compound 4, half-maximal inhibitory concentration: 88700 nM
Compound 4: middle estimate off by 1.1-fold (0.03 log units), on the high side, and the stated range covers the measured number.
By their numbers in this assay, from the lowest: compounds 3, 1 and 4 (each within the scatter of the next). At a limit, above all of these: compound 2.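

In this assay, pyrrolidin-1-yl in place of cyclohexylamino on a carbonyl carbon gives a 1.9-fold higher number from compound 3 to compound 4 (0.27 log units; within the scatter), so at this position the two groups are not separated, although only cyclohexylamino carries a hydrogen-bond donor. Pyrrolidin-1-yl in place of morpholin-4-yl gives an at least 1.4-fold lower number from compound 2 to compound 4 (0.15 log units; that floor lies within the scatter), so the data do not separate these two rings either, and the beyond-scatter step of an at least 2.7-fold lower number from compound 2 to compound 3 (0.43 log units; beyond the scatter) does not extend to a general split between cyclic tertiary and secondary amides. Compound 2 stands at a limit, not a number: the limit of > 128000 nM in this assay, at which 1 of the 4 values shown sits.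

Still open, going by these compounds, is how a piperidin-1-yl or an open-chain dimethylamino group on the same carbonyl carbon would read in this assay. Also open, on these data alone, is whether a methyl group on the cyclohexylamino nitrogen would shift the number.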